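Pyridine for Benzene on the Cyclopropyl Acid

The source may report more compounds than this note shows. Statements on the series, on what has been measured and on what is new or still open speak of the compounds shown alone.

compound 1 `CS(=O)(=O)NC(=O)c1ccc(C2CC2c2ccc(OCc3c(-c4c(Cl)cccc4Cl)noc3C3CC3)cc2Cl)cc1` gives 90 nM
compound 2 `O=C(O)c1cccc([C@H]2C[C@@H]2c2ccc(OCc3c(-c4c(Cl)cccc4Cl)noc3C3CC3)cc2Cl)c1` gives 219 nM
compound 3 `O=C(O)c1cccc(C2CC2c2ccc(OCc3c(-c4c(Cl)cccc4Cl)noc3C3CC3)cc2Cl)c1` gives 32 nM

In an assay on isolated protein for agonist activity at Bile acid receptor (Homo sapiens), read by FRET (on this read-out higher numbers stand for an effect only at larger amounts of compound and lower numbers for an effect already at smaller amounts), compound 3 stands lowest of the three numbers, nearest to compound 1 and furthest from compound 2. Within the data shown here, the one step counted among them, a 6.8-fold lower number from compound 2 to compound 3 (0.84 log units; beyond the scatter), concerns the fact that one of compounds 2 and 3 is drawn with a defined configuration and the other without, at the place where they differ and touches nothing on the carboxyphenyl side. Compound 4 `O=C(O)c1cncc(C2CC2c2ccc(OCc3c(-c4c(Cl)cccc4Cl)noc3C3CC3)cc2Cl)c1` differs from compound 3 by 5-carboxypyridin-3-yl in place of 3-carboxyphenyl on a saturated ring carbon. Among the measured compounds shown here, no measured step changes this ring, so the expectation rests on compound 3 alone, and a small shift in either direction would stay within the range one allows. A modest move toward a higher number is taken as the estimate, a 1.9-fold higher number from compound 3 to compound 4 (0.27 log units; within the scatter). Compound 4 is therefore expected to give about 60 nM, between 20 nM and 200 nM.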

Compound 4, half-maximal effective concentration: 10 nM
Compound 4: middle estimate off by 6.0-fold (0.78 log units), on the high side; measured number below the stated range.
By their numbers in this assay, from the lowest: compound 4; then compound 3; then compound 1; then compound 2.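

In this assay, 5-carboxypyridin-3-yl in place of 3-carboxyphenyl gives a 3.2-fold lower number from compound 3 to compound 4 (0.51 log units; beyond the scatter), the first sign that the number responds to a change in this ring on the cyclopropyl carbon. The wider gap, a 22-fold lower number from compound 2 to compound 4 (1.34 log units; beyond the scatter), cannot be credited to the ring alone, because that pair also carries the earlier difference: the fact that one of compounds 2 and 3 is drawn with a defined configuration and the other without, at the place where they differ

The compounds shown leave open whether the lower number holds for a single defined configuration of the cyclopropyl ring. They also leave open how an amine or a fluorine added to the pyridine ring would read.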